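This account rests on a few compounds, and the source may have more. Where it says the series, first, only, none or still open, it means among the compounds named here.

Measured so far in a functional assay on PANC-1 cells (Homo sapiens) for cytotoxicity, read by MTT assay, with a stated time of 72 h, tested at 10 uM; a lower number here means a stronger effect, a higher number a weaker effect of the compound at the concentration tested:
- compound 1, `C=C1C(=O)O[C@@H](c2ccccc2)[C@H]1c1ccccc1`, gives 38%
- compound 2, `C=C1C(=O)O[C@H](c2ccccc2)[C@H]1c1ccccc1`, gives 1%

Compound 2 stands lowest of the two numbers, which in this read-out means the stronger effect of the two. Going by the values given here, its only neighbour is compound 1, and the step between them is a number 37 percentage points lower from compound 1 to compound 2 (beyond the scatter). The two compounds share every atom and bond; what separates them is the fact that compounds 1 and 2 differ only in the configuration as drawn, a single stereocentre at a saturated ring carbon drawn one way in compound 1 and the other way in compound 2.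

The next compound, compound 3, `C=C1C(=O)O[C@H](c2ccc(C(F)(F)F)cc2)[C@H]1c1ccccc1`, keeps the configuration of compound 2 and changes a group instead: trifluoromethyl in place of hydrogen on an aromatic carbon. The trifluoromethyl sits on an aromatic carbon of a six-membered aromatic ring of carbon only, para to a large group. Among the compounds with values here, the one measured step concerns configuration alone, so no measured step speaks to swapping a hydrogen for a trifluoromethyl on this ring. With nothing to lean on, the expectation for compound 3 is a step within the usual scatter, a number 9 percentage points higher from compound 2 to compound 3 (within the scatter). The estimate for compound 3 in this assay is therefore 10%, in a range from -8% to 40%.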

Compound 3, a percentage reported as activity, at one concentration (the size of the read-out at that concentration, not a potency): 33%
Compound 3: the middle estimate sits 23 percentage points below what was measured; the measured number falls inside the stated range.
By their numbers in this assay, from the lowest: compound 2; then compounds 3 and 1 (each within the scatter of the next).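

In this assay, trifluoromethyl in place of hydrogen on an aromatic carbon, para to a large group, gives a number 32 percentage points higher from compound 2 to compound 3 (beyond the scatter), and a higher number here means a weaker effect at the concentration tested. Going by these compounds alone, this position on the ring is therefore not a neutral place to make a change: until now, the only measured change was one of configuration, a number 37 percentage points lower from compound 1 to compound 2 (beyond the scatter), and this first change of a group is also large and takes away much of the effect seen with compound 2. The compounds shown offer no measurement that explains why this group at this position weakens the effect.

Going by these compounds, it remains open whether the loss belongs to trifluoromethyl itself or would also follow from other groups at the same position, such as a fluorine atom, a methoxy group, an amine or a carboxylic acid. On these data alone, it is equally open what trifluoromethyl would do on the other aromatic ring of the shared core, or on the configuration of compound 1, where the starting number is different.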